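From nitro to sulfamoyl in a weak series

A few compounds are considered here, and "the series" means these few. Any claim that something is new, unique, unknown or untested is made for them only; others in the source may bear on it.

Measured in a functional assay on CCRF-CEM cells (Homo sapiens) for inhibition; on this read-out lower numbers stand for stronger inhibition and higher numbers for weaker inhibition (each value is a limit):
- Compound 1 `C#CCN(Cc1ccc2nc(C)nc(O)c2c1)c1cccc(C)c1` has the limit > 5000 nM
- Compound 2 `C#CCN(Cc1ccc2nc(C)nc(O)c2c1)c1cccc(C(F)(F)F)c1` has the limit > 4300 nM
- Compound 3 `C#CCN(Cc1ccc2nc(C)nc(O)c2c1)c1ccc([N+](=O)[O-])cc1` has the limit > 4800 nM

Compound 3 is known only by the limit > 4800 nM and not by an exact number. Compound 4 `C#CCN(Cc1ccc2nc(C)nc(O)c2c1)c1ccc(S(N)(=O)=O)cc1` carries sulfamoyl in place of nitro on an aromatic carbon and is otherwise the same. Among the measured compounds shown here, the only measured step is a step that the two limits leave unreadable from compound 1 to compound 2 and it offers no size to carry over. Since all three compounds stop at limits, weak inhibition is expected to continue in this assay with no clear shift in either direction. The expected step is a step that the limit leaves unreadable from compound 3 to compound 4 and it remains an estimate. For compound 4 the estimated value is 5000 nM with an expected range from 1800 nM to 15000 nM and a limit is quite likely.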

Compound 4, half-maximal inhibitory concentration: > 26000 nM
Compound 4: a limit, no number; the forecaster's own chance of this, stated with the estimate: 70%; at least 5.2-fold (0.71 log units) between middle value and limit.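

Compound 3 and compound 4 are both known only as limits, and the step from nitro to sulfamoyl cannot be read in this assay. None of the compounds shown has an exact number, which leaves open how strongly each one inhibits.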